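The source may hold more compounds than are shown below. What is called first, only, known or untested is meant among the compounds shown, and "the series" means these compounds.

In an ADME assay on L6 cells (Rattus norvegicus) for cytotoxicity, read by resazurin assay, with a stated time of 70 h (on this read-out lower numbers stand for stronger inhibition and higher numbers for weaker inhibition), compound 1 `CC(=O)Oc1ccc2c(c1)C(C)=CC(C)(C)N2Cc1ccc(C#N)cc1` gives 29000 nM and compound 2 `CC(=O)Oc1ccc2c(c1)C(C)=CC(C)(C)N2Cc1ccc(F)cc1` gives 29000 nM as well, so compound 2 stands level with compound 1. Compound 3 `COc1ccc(CN2c3ccc(OC(C)=O)cc3C(C)=CC2(C)C)cc1` has methoxy in place of fluoro on an aromatic carbon, para to a large group methoxy in place of fluoro on an aromatic carbon on the shared core. Within the data shown here, the only measured step of no change at the digits printed from compound 1 to compound 2 (within the scatter) stayed within the scatter and changed the group on that same carbon, so one step is the whole guide. No step beyond the scatter is expected in this assay here. The expected step is no change at the digits printed from compound 2 to compound 3 (within the scatter) on this thin evidence. For compound 3 the expected value is 29000 nM (estimated range 14000 nM to 58000 nM).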

Compound 3, half-maximal inhibitory concentration: 15000 nM
Beside the measured number, compound 3's estimate is 1.9-fold (0.29 log units) above it; the measured number falls inside the stated range.
By their numbers in this assay, from the lowest: compounds 3, 1 and 2 (each within the scatter of the next).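

In this assay, methoxy in place of fluoro on this aromatic carbon gives a 1.9-fold lower number from compound 2 to compound 3 (0.29 log units; within the scatter) and methoxy in place of cyano gives a 1.9-fold lower number from compound 1 to compound 3 (0.29 log units; within the scatter). Among these compounds, with methoxy, this position para to a large group has now carried three different groups, including one that adds an oxygen, and no step among them lies beyond the scatter. No measured finding bears on these steps.

As far as these compounds go, whether an amine or a carboxylic acid on this carbon would move the number beyond the scatter remains open. The compounds shown also leave open how changes elsewhere on the shared core would read.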